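Replacing the 3,5-dimethoxyphenyl group of compound 3

The compounds below may be only part of what the source reports. "The series", "measured", "known", "first", "only" and "open" are said of these compounds alone.

- compound 1 `O=C(CCc1cccc2c1B(O)OC2)Nc1cccc(I)c1` gives 630 nM
- compound 2 `C#Cc1cccc(NC(=O)CCc2cccc3c2B(O)OC3)c1` gives 980 nM
- compound 3 `COc1cc(OC)cc(-c2cccc(NC(=O)CCc3cccc4c3B(O)OC4)c2)c1` gives 44 nM

In a functional assay on SK-OV-3 cells (Homo sapiens) for antiproliferative activity, read by MTT assay, with a stated time of 72 h (on this read-out lower numbers stand for stronger inhibition and higher numbers for weaker inhibition), compound 3 has the lowest number of the three. Compound 4 `N#Cc1ccc(-c2cccc(NC(=O)CCc3cccc4c3B(O)OC4)c2)cc1` differs from it in one place, with 4-cyanophenyl in place of 3,5-dimethoxyphenyl (4-cyanophenyl in place of 3,5-dimethoxyphenyl on an aromatic carbon). Going by the values given here, two measured steps bear on this swap. Both a 14-fold lower number from compound 1 to compound 3 (1.16 log units; beyond the scatter) and a 22-fold lower number from compound 2 to compound 3 (1.35 log units; beyond the scatter) are large, and each puts the 3,5-dimethoxyphenyl where iodo or ethynyl stood. By contrast, a 1.6-fold higher number from compound 1 to compound 2 (0.19 log units; within the scatter) stays within the scatter. Among the compounds with values here, no measured step exchanges one aromatic ring for another, so these steps guide the expectation only loosely. Compound 4 still carries an aromatic ring at that place, so it is expected to keep much of the gain, though probably not all of it. An estimated move to a higher number in this assay is expressed as a 3.0-fold higher number from compound 3 to compound 4 (0.47 log units; beyond the scatter) and would be moderate in size. Compound 4 is expected at 130 nM in this assay (estimated range 30 nM to 500 nM).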

Compound 4, half-maximal inhibitory concentration: 340 nM
Compound 4: middle estimate off by 2.6-fold (0.42 log units), on the low side; low and high end bracket the measured number.
By their numbers in this assay, from the lowest: compound 3; then compounds 4, 1 and 2 (each within the scatter of the next, the first and the last beyond it).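

In this assay, an aromatic ring at this place does not by itself secure a low number: a 7.7-fold higher number from compound 3 to compound 4 (0.89 log units; beyond the scatter) shows that the outcome depends on which ring is attached. Against the smaller groups, the 4-cyanophenyl ring gives a mixed picture, with a 2.9-fold lower number from compound 2 to compound 4 (0.46 log units; beyond the scatter) against ethynyl, while a 1.9-fold lower number from compound 1 to compound 4 (0.27 log units; within the scatter) against iodo leaves the two compounds indistinguishable. No measurement shown here accounts for the gap between the 3,5-dimethoxyphenyl and 4-cyanophenyl rings.

Going by these compounds, the two rings differ both in the groups they carry and in where they carry them, so it remains open whether the methoxy groups, the nitrile or their placement matters. A plain phenyl ring or a 4-methoxyphenyl ring at this place would help separate these possibilities.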